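Lengthening an Alkyl Chain on the Shared Core

This account rests on a few compounds, and the source may have more. Where it says the series, first, only, none or still open, it means among the compounds named here.

compound 1 `CSc1nc2ccc(C)cn2c(=N)c1S(=O)(=O)c1ccccc1` — 1.3 nM
compound 2 `CSc1nc2cc(C)ccn2c(=N)c1S(=O)(=O)c1ccccc1` — 41 nM
compound 3 `CCc1ccn2c(=N)c(S(=O)(=O)c3ccccc3)c(SC)nc2c1` — 80 nM

Of the compounds shown here, three sharing one core have been measured in an assay on HeLa cells for displacement of a labelled ligand from 5-hydroxytryptamine receptor 6 (Homo sapiens); a lower number here means a stronger inhibitor, a higher number a weaker inhibitor. Compound 3 has the highest number of the three; its nearest neighbour is compound 2, which is close enough that the two cannot be told apart, while compound 1 gives a number far lower than compound 3.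

The next compound is compound 4 `CCCc1ccn2c(=N)c(S(=O)(=O)c3ccccc3)c(SC)nc2c1`. It differs from compound 3 in one place: methyl in place of hydrogen on a saturated chain carbon, two bonds along the chain from an aromatic carbon. Going by the values given here, the only measured step that bears on this change is the one within the scatter from compound 2 to compound 3, a 2.0-fold higher number from compound 2 to compound 3 (0.29 log units; within the scatter), where a hydrogen on the chain bound to the aromatic carbon was likewise replaced by methyl. Adding one more carbon in the same direction has given no clear movement so far, so for compound 4 the expected step in this assay is small, with no certainty of direction, but with a slight lean towards a higher number.

Compound 4 is therefore expected to give about 110 nM in this assay, with a range from 40 nM to 300 nM, which corresponds to an expected step of a 1.4-fold higher number from compound 3 to compound 4 (0.14 log units; within the scatter).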

Compound 4, half-maximal inhibitory concentration: 700 nM
Compound 4: the middle estimate sits 6.4-fold (0.80 log units) below what was measured, outside the stated range (above it).
By their numbers in this assay, from the lowest: compound 1; then compounds 2 and 3 (each within the scatter of the next); then compound 4.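

In this assay, the length of this chain now matters: the same added methyl that left no clear movement from methyl to ethyl, a 2.0-fold higher number from compound 2 to compound 3 (0.29 log units; within the scatter), gives a change beyond the scatter from ethyl to propyl, an 8.8-fold higher number from compound 3 to compound 4 (0.94 log units; beyond the scatter). Read across the whole extension from methyl to propyl, the result is a 17-fold higher number from compound 2 to compound 4 (1.23 log units; beyond the scatter), so the effect of one added methyl at this position depends on the chain it is added to and does not build evenly from one carbon to the next. Nothing shown here accounts for this sharp change between ethyl and propyl, and its origin remains unexplained.

The compounds shown leave open whether a longer chain such as butyl would carry the number further up or leave it level, and whether branched isopropyl, with the same carbons as propyl, would behave like propyl. They also leave open whether an amine or a hydroxyl group at the end of the propyl chain would return the number towards that of compound 2 at 41 nM in this assay.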